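One Nitro-to-Chloro Swap Measured Once, Expected Again

The source may hold more compounds than are shown below. What is called first, only, known or untested is meant among the compounds shown, and "the series" means these compounds.

Compound 1, `COc1cc(C2=NN(C(C)=O)C(c3ccc(Cl)c(Cl)c3)O2)cc(OC)c1OC`, gives 26.1% in a functional assay on PC-3 cells (Homo sapiens) for antiproliferative activity, read by MTT assay, tested at 5 uM; on this read-out lower numbers stand for a weaker effect and higher numbers for a stronger effect at the one concentration tested.
Compound 2, `COc1cc(C(=O)N/N=C/c2ccc(Cl)c([N+](=O)[O-])c2)cc(OC)c1OC`, gives 42.3% in this assay.
Compound 3, `COc1cc(C2=NN(C(C)=O)C(c3ccc(Cl)c([N+](=O)[O-])c3)O2)cc(OC)c1OC`, gives 61.4% in this assay.

Of the compounds shown here, three have been measured in this assay. Compound 3 stands highest, compound 2 second, and compound 1 lowest, each gap lying beyond the usual scatter. Compound 3 and compound 1 share a core and differ in one place only: chloro in place of nitro on an aromatic carbon. That single change produced a number 35.3 percentage points lower from compound 3 to compound 1 (beyond the scatter), a large drop.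

Compound 4, `COc1cc(C(=O)N/N=C/c2ccc(Cl)c(Cl)c2)cc(OC)c1OC`, has not yet been measured. It relates to compound 2 exactly as compound 1 relates to compound 3: chloro in place of nitro on an aromatic carbon. Among the measured compounds shown here, compound 2 and compound 3 carry different cores, and the difference between the two cores is not broken down here; what is known is only that compound 3 sits above compound 2 in this assay.

The same change is therefore being made a second time, on a second core. For the measured compounds named here, the step is expected to be a number 30.3 percentage points lower from compound 2 to compound 4 (beyond the scatter), with a somewhat cautious size, because a number 35.3 percentage points lower from compound 3 to compound 1 (beyond the scatter) was observed on the other core and there is no second example on which to rest its transfer. On that basis compound 4 is estimated at 12% in this assay, and the expected range runs from 0% to 30%.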

Compound 4, a percentage reported as inhibition, at one concentration (the size of the read-out at that concentration, not a potency): 31.6%
Compound 4: the middle estimate sits 19.6 percentage points below what was measured; the whole stated range lies below it.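

In this assay, chloro in place of nitro on an aromatic carbon lowered the number on the second core as well, giving a number 10.7 percentage points lower from compound 2 to compound 4 (beyond the scatter), so the direction of the change held on both cores shown. The size of the step did not carry over, and the two steps differ by more than the scatter allows: the same change on two cores in this assay, a number 35.3 percentage points lower (beyond the scatter) from compound 3 to compound 1 and a number 10.7 percentage points lower (beyond the scatter) from compound 2 to compound 4, 24.6 percentage points apart, beyond the scatter of two such steps This shows that, in this series, the earlier step could be relied on for its sign but not for its size, and it does not show what in the two cores sets the size, nor how the change would behave on any third core, since two cores give one comparison and the difference between them is not broken down.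

Nitro and chloro are the only groups compared at this aromatic carbon, so what an amine, a nitrile or a trifluoromethyl group would give there remains open, as does whether such groups would keep the same order on both cores. Each value also comes from a single concentration, so the steps seen here describe a weaker effect at that concentration only and leave open what would be seen at any other concentration.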